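Replacing the methoxy of compound 1 by a dicyanoethenyl group

This account rests on a few compounds, and the source may have more. Where it says the series, first, only, none or still open, it means among the compounds named here.

Measured in a functional assay (trachea) with Rattus norvegicus as the target; a lower number here means a less potent compound, a higher number a more potent compound, by a factor of ten per unit of this negative logarithm:
compound 1 `COc1ccc2c(c1)C(n1ccccc1=O)=CC(C)(C)O2`: 5.99
compound 2 `CC(=O)c1ccc2c(c1)C(n1ccccc1=O)=CC(C)(C)O2`: 6.65
compound 3 `CC1(C)C=C(n2ccccc2=O)c2cc(C(=O)c3ccc(O)cc3)ccc2O1`: 5.87

Compound 1 stands second highest of the three numbers in this assay. Its nearest neighbour is compound 3, which differs from it only within the scatter, and its furthest is compound 2, which lies clearly higher.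

The compound to be measured next is compound 4 `CC1(C)C=C(n2ccccc2=O)c2cc(C=C(C#N)C#N)ccc2O1`. Relative to compound 1 the change is 2,2-dicyanoethenyl in place of methoxy on an aromatic carbon.

Two measured steps start from the same methoxy of compound 1 and so bear on this one. Exchanging the methoxy for an acetyl gave a number 0.66 log units higher from compound 1 to compound 2 (beyond the scatter), a modest gain beyond the scatter. Exchanging it for the much larger (4-hydroxyphenyl)carbonyl gave a number 0.12 log units lower from compound 1 to compound 3 (within the scatter), nothing beyond the scatter. The further step a number 0.78 log units lower from compound 2 to compound 3 (beyond the scatter) shows that enlarging the acetyl cost what the acetyl had won. The dicyanoethenyl is a small substituent with two hydrogen-bond acceptors, closer in size to the acetyl of compound 2 than to the substituent of compound 3, so a modest rise in this assay is expected rather than none, tempered by the flat result for compound 3.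

For compound 4 the expected step is a number 0.41 log units higher from compound 1 to compound 4 (beyond the scatter). Compound 4 is therefore estimated at 6.4, within 5.8 to 7.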

Compound 4, logarithm of the reciprocal of the active concentration, log(1/C): 6.3
The estimate for compound 4 lay 0.10 log units above the measured number; the measured number falls inside the stated range.
By their numbers in this assay, from the lowest: compounds 3 and 1 (each within the scatter of the next); then compound 4; then compound 2.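

In this assay the step of a number 0.31 log units higher from compound 1 to compound 4 (beyond the scatter) shows that a gain at this aromatic carbon does not depend on the acetyl of compound 2, since a 2,2-dicyanoethenyl with no carbonyl of its own also lifts the number beyond the scatter. The same replacement still falls short of the acetyl by the step of a number 0.35 log units lower from compound 2 to compound 4 (beyond the scatter) and clears the (4-hydroxyphenyl)carbonyl by the step of a number 0.43 log units higher from compound 3 to compound 4 (beyond the scatter) at this single position, so the three replacements of the methoxy now fall into an order with acetyl on top, 2,2-dicyanoethenyl in the middle and (4-hydroxyphenyl)carbonyl last. No measurement on these compounds accounts for that order.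

As far as these compounds go, it remains open whether a single nitrile or a simple amine on this carbon would match the acetyl or the 2,2-dicyanoethenyl. From the compounds shown here alone, it is equally open whether a carboxylic acid or a longer acyl chain such as butanoyl would hold the gain or lose it, as the (4-hydroxyphenyl)carbonyl does.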